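Swapping One Side Group on a Weakly Active Compound

This account rests on a few compounds, and the source may have more. Where it says the series, first, only, none or still open, it means among the compounds named here.

Within the data shown here, in a functional assay on A549 cells (Homo sapiens) for inhibition, read by MTT assay, with a stated time of 72 h (on this read-out lower numbers stand for stronger inhibition and higher numbers for weaker inhibition), compound 2 (`CC(C)(C)Oc1ccc(-c2nnc(SCCCN3CCN(c4nc5ccccc5s4)CC3)o2)cc1`) gives 71600 nM and compound 1 (`O=C(NCc1nnc(SCCCN2CCN(c3nc4ccccc4o3)CC2)o1)c1ccccc1`) gives 102000 nM as the only two numbers so far. These two numbers lie within the usual scatter of repeated measurements, so compound 2 stands level with compound 1 and neither can be ranked above the other. Both numbers are large, which on this read-out means weak inhibition.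

Compound 3 (`O=C(NCc1nnc(SCCCN2CCN(c3nc4ccccc4s3)CC2)o1)c1ccccc1`) has not yet been measured. The change from compound 2 (benzamidomethyl in place of 4-(tert-butoxy)phenyl on an aromatic carbon) puts benzamidomethyl in place of 4-(tert-butoxy)phenyl on an aromatic carbon. Among the measured compounds shown here, no measured pair differs in just one place, so nothing shows directly what such a swap does. One hint remains: compound 1 also carries benzamidomethyl, and it gives 102000 nM in this assay with no gap beyond the scatter from compound 2. A step beyond the scatter is therefore not expected in either direction. The estimated step (a 1.2-fold higher number from compound 2 to compound 3 (0.07 log units; within the scatter)) is small and stays within the scatter. For compound 3 the expected value is 85000 nM (estimated range 35000 nM to 200000 nM).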

Compound 3, half-maximal inhibitory concentration: 88700 nM
The estimate for compound 3 lay 1.0-fold (0.02 log units) below the measured number, and the stated range covers the measured number.
By their numbers in this assay, from the lowest: compounds 2, 3 and 1 (each within the scatter of the next).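

In this assay, among these compounds, the first direct reading at the aromatic carbon of the five-membered aromatic ring comes from putting benzamidomethyl in place of 4-(tert-butoxy)phenyl, and the step is a 1.2-fold higher number from compound 2 to compound 3 (0.09 log units; within the scatter), so this swap leaves no readable difference even though it adds a hydrogen-bond donor. Among the compounds shown here, compound 3 also gives a first direct reading at a second place, with 1,3-benzothiazol-2-yl in place of 1,3-benzoxazol-2-yl on an amine nitrogen in a ring, and that step is a 1.1-fold lower number from compound 1 to compound 3 (0.06 log units; within the scatter), again no readable difference. Each of these two single swaps therefore stays within the scatter in this weakly active set, and no accompanying measurement bears on the reason for this.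

From the compounds shown here alone, both groups seen on that aromatic carbon hold a six-membered aromatic ring of carbon only, so it remains open what a small amine or a carboxylic acid would give there. Going by these compounds, a longer chain in the linker of the shared core is equally open, as is whether any change to this core can bring much stronger inhibition.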